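This account rests on a few compounds, and the source may have more. Where it says the series, first, only, none or still open, it means among the compounds named here.

Three compounds share one core and differ only in the aromatic group attached to the carbon with a double bond to nitrogen. Compound 1 `Cn1c(=O)c(=O)n(C2CCCC2)c2nc(N/N=C/c3ccc(O)c(F)c3)ncc21` carries a 3-fluoro-4-hydroxyphenyl group there, and in a functional assay on HCT-116 cells (Homo sapiens) for antiproliferative activity, read by MTT assay (a lower number here means a stronger inhibitor, a higher number a weaker inhibitor), compound 1 gives 59300 nM. Compound 2 `Cn1c(=O)c(=O)n(C2CCCC2)c2nc(N/N=C/c3ccc(C(F)(F)F)cc3)ncc21` carries a 4-(trifluoromethyl)phenyl group, and in this assay compound 2 gives 29000 nM. Compound 3 `Cn1c(=O)c(=O)n(C2CCCC2)c2nc(N/N=C/c3cccc(Cl)c3Cl)ncc21` carries a 2,3-dichlorophenyl group, and in this assay compound 3 gives 26400 nM. Of these three numbers that of compound 1 is the highest, so it is the weakest inhibitor of the set: the number falls by a 2.0-fold lower number from compound 1 to compound 2 (0.31 log units; beyond the scatter) and by a 2.2-fold lower number from compound 1 to compound 3 (0.35 log units; beyond the scatter), while the gap a 1.1-fold lower number from compound 2 to compound 3 (0.04 log units; within the scatter) is within the scatter.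

Compound 4 `COc1ccc(/C=N/Nc2ncc3c(n2)n(C2CCCC2)c(=O)c(=O)n3C)c(OC)c1` has not yet been measured. It differs from compound 1 in a single place: 2,4-dimethoxyphenyl in place of 3-fluoro-4-hydroxyphenyl on a carbon with a double bond to nitrogen. The two measured steps that bear on this change both also remove the 3-fluoro-4-hydroxyphenyl group of compound 1 and put a different aromatic group in its place, and both produced a modest lowering of the number. A modest lowering is therefore expected here too, though a third replacement need not behave like the first two. The estimate for compound 4 in this assay is 32000 nM, with a range from 13000 nM to 80000 nM. This estimate corresponds to an expected step of a 1.9-fold lower number from compound 1 to compound 4 (0.27 log units; within the scatter).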

Compound 4, half-maximal inhibitory concentration: > 100000 nM
Compound 4: a limit, no number; the forecaster's own chance of this, stated with the estimate: 15%; at least 3.1-fold (0.49 log units) between middle value and limit.
By their numbers in this assay, from the lowest: compounds 3 and 2 (each within the scatter of the next); then compound 1. At a limit, above all of these: compound 4.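

In this assay compound 4 gives no number, only a limit of the assay: the limit of > 100000 nM in this assay, at which 1 of the 4 values shown sits.

Going by these compounds alone, replacing the 3-fluoro-4-hydroxyphenyl group had so far lowered the number, but 2,4-dimethoxyphenyl at this place gives an at least 1.6-fold higher number from compound 1 to compound 4 (0.22 log units; that floor lies within the scatter), so the floor alone does not firmly separate this change from the starting compound, and it shows no lowering like the two earlier replacements. The clearer result lies in the comparisons with the two stronger compounds, with 2,4-dimethoxyphenyl giving an at least 3.7-fold higher number from compound 3 to compound 4 (0.57 log units; beyond the scatter) in place of 2,3-dichlorophenyl and an at least 3.4-fold higher number from compound 2 to compound 4 (0.53 log units; beyond the scatter) in place of 4-(trifluoromethyl)phenyl, which shows that the choice of aromatic group on the carbon with a double bond to nitrogen can matter more than the first three compounds suggested.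

Because compound 4 carries two methoxy groups, these compounds leave open whether one methoxy group alone, as in a 4-methoxyphenyl group, would give a measurable number. They also leave open how an amine or a carboxylic acid on the ring, or a plain unsubstituted phenyl group, would compare at this place.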